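The source may hold more compounds than are shown below. What is called first, only, known or untested is meant among the compounds shown, and "the series" means these compounds.

Compound 1 `O=C(O)C[C@@H](NC(=O)[C@@H]1CCCN1S(=O)(=O)c1cc(Cl)cc(Cl)c1)c1ccc(O)cc1`: 0.74 nM in an assay on RPMI-8866 cells for inhibition of integrin alpha-4/beta-1 (Homo sapiens); a higher number here means a weaker inhibitor, a lower number a stronger inhibitor
Compound 2 `O=C(O)C[C@@H](NC(=O)[C@@H]1CCN1S(=O)(=O)c1cc(Cl)cc(Cl)c1)c1ccc(OC2CCCC2)cc1`: 0.5 nM

Compound 1 has the higher of the two numbers in this assay; compound 2 sits a little lower, yet the two values lie within the scatter of this assay, so no order between them can be read. Compound 3 `O=C(O)C[C@@H](NC(=O)[C@@H]1CCCN1S(=O)(=O)c1cc(Cl)cc(Cl)c1)c1ccc(OC(F)(F)F)cc1` is not yet measured. It differs from compound 1 in one place: trifluoromethyl in place of hydrogen on an oxygen on an aromatic ring. Among the measured compounds shown here, no measured pair shows this change, so no step size is known; the expectation is for no step beyond the scatter, that is, a 1.2-fold lower number from compound 1 to compound 3 (0.09 log units; within the scatter). Compound 3 is therefore estimated at 0.6 nM, with a range from 0.2 nM to 2.5 nM.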

Compound 3, half-maximal inhibitory concentration: 2.6 nM
Compound 3: middle estimate off by 4.3-fold (0.64 log units), on the low side, outside the stated range (above it).
By their numbers in this assay, from the lowest: compounds 2 and 1 (each within the scatter of the next); then compound 3.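

In this assay, going from hydroxy to trifluoromethoxy on the aromatic ring gives a 3.5-fold higher number from compound 1 to compound 3 (0.55 log units; beyond the scatter) and shows that this oxygen is not indifferent to what it carries. Here, replacing its hydrogen with trifluoromethyl yields a modestly weaker inhibitor, a cost that the two earlier compounds could not reveal. No measurement at hand explains this step. Still open, on these data alone, is how methoxy or a longer chain on this oxygen would compare with hydroxy, and whether an amine in place of the hydroxy would hold the strength of compound 1.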